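The compounds below may be only part of what the source reports. "The series", "measured", "known", "first", "only" and "open" are said of these compounds alone.

Measured compounds:
compound 1 `CCn1nnc(-c2sc(-c3cccc(N)c3)nc2O)n1` — 61 nM
compound 2 `CCOC(=O)c1sc(-c2ccccc2)nc1OC` — > 100000 nM

For the measured compounds named here, in an assay on HEK293 cells for inhibition of transient receptor potential cation channel subfamily M member 8 (Homo sapiens), read by FLIPR, with stated times of 5 min and 3 min (a lower number here means a stronger inhibitor, a higher number a weaker inhibitor), compound 1 gives 61 nM, the only numerical value in the set. Compound 2 returns > 100000 nM, which is a limit of this assay rather than a number, as noted in the limit of > 100000 nM in this assay, at which 1 of the 2 values shown sits. Going by the values given here, no pair of measured compounds differs in a single place, so no measured step is available; the two values show only that compound 1 is an inhibitor with a number against it while compound 2 returns a limit.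

Compound 3 `CCn1nnc(-c2sc(-c3cccc(NC)c3)nc2O)n1` has not yet been measured. Relative to compound 1 the change is methyl in place of hydrogen on a nitrogen on an aromatic ring. Among the compounds with values here, the step expected here, a 1.1-fold higher number from compound 1 to compound 3 (0.06 log units; within the scatter), is small, within the usual scatter of this assay and with no firm direction, since no measured step in the set speaks to this change. Compound 3 is therefore estimated at 70 nM, with a range from 20 nM to 250 nM.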

Compound 3, half-maximal inhibitory concentration: 1020 nM
Compound 3: middle estimate off by 15-fold (1.16 log units), on the low side; the whole stated range lies below it.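

In this assay, for the compounds shown here, amino to methylamino gives a 17-fold higher number from compound 1 to compound 3 (1.22 log units; beyond the scatter), the first single change with a measured effect. Going by these compounds alone, the nitrogen on an aromatic ring is therefore a sensitive place in this pair: one added methyl, a single heavy atom with no ring and no net charge, moves the value well beyond the scatter, whereas the earlier compounds offered no step from which to judge any position. Nothing at hand gives a measured reason for this loss of potency.

As far as these compounds go, it remains open whether the loss belongs to methyl alone or extends to other replacements of hydrogen on this nitrogen, such as an ethyl chain, a second methyl giving a dimethylamino group, or an acetyl group giving an amide, and whether any of these would restore the value of compound 1. Within the data shown here, compound 2 gives > 100000 nM, a limit and not a number, and no step links it to this nitrogen.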